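The compounds below may be only part of what the source reports. "The series", "measured", "known", "first", "only" and "open" are said of these compounds alone.

Going by the values given here, in a functional assay on HT-29 cells (Homo sapiens) for antiproliferative activity, read by sulforhodamine B assay, with a stated time of 48 h (on this read-out higher numbers stand for weaker inhibition and lower numbers for stronger inhibition), compound 2 `CCCC(=O)Nc1ccc(S(=O)(=O)Oc2ccccc2I)cc1` gives 11000 nM, the higher of the two numbers known so far; compound 1 `CCCC(=O)Nc1ccc(S(=O)(=O)Oc2ccccc2C(C)C)cc1` gives 4900 nM, and a 2.2-fold higher number from compound 1 to compound 2 (0.35 log units; beyond the scatter). Among the compounds with values here, compound 3 `CCCCCC(=O)Nc1ccc(S(=O)(=O)Oc2ccccc2I)cc1` differs from compound 2 by ethyl in place of hydrogen on a saturated chain carbon, three bonds along the chain from a carbonyl carbon, an extension of the amide chain that no measured step addresses: the single known step alters the substituent on the aromatic ring, not the chain. With nothing bearing on this change, no step beyond the scatter is expected. The estimated step reads no change at the digits printed from compound 2 to compound 3 (within the scatter). Compound 3 is therefore expected at 11000 nM, within a range of 4000 nM to 30000 nM.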

Compound 3, half-maximal inhibitory concentration: 13000 nM
Compound 3: the middle estimate sits 1.2-fold (0.07 log units) below what was measured, and the stated range covers the measured number.
By their numbers in this assay, from the lowest: compound 1; then compounds 2 and 3 (each within the scatter of the next).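

In this assay, ethyl in place of hydrogen on a saturated chain carbon, three bonds along the chain from a carbonyl carbon, gives a 1.2-fold higher number from compound 2 to compound 3 (0.07 log units; within the scatter) and so no step beyond the scatter at this position, with the iodo group held in place. Going by these compounds alone, the earlier step concerned only the substituent on the aromatic ring, so this is the only reading on the amide chain. Nothing available explains this result.

Going by these compounds, whether the chain change behaves the same way with isopropyl in place of iodo remains open. A longer chain, or an amine or a carboxylic acid at the chain end, also remains untested in the compounds shown here.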